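Working notes: from compound 3 to compound 4

The source may hold more compounds than are shown below. What is called first, only, known or untested is meant among the compounds shown, and "the series" means these compounds.

Measured so far in a functional assay on DU-145 cells (Homo sapiens) for cytotoxicity, read by MTT assay, with a stated time of 24 h; a lower number here means a stronger inhibitor, a higher number a weaker inhibitor
compound 1 `O=C1/C(=C/c2ccccc2F)CN(Cc2cn(Cc3cccc(Cl)c3)nn2)C/C1=C\c1ccccc1F` gives 4300 nM
compound 2 `Cc1ccc(/C=C2\CN(Cc3cn(Cc4ccc(F)cc4)nn3)C/C(=C\c3ccc(C)cc3)C2=O)cc1` gives 49700 nM
compound 3 `Cc1ccc(/C=C2\CN(Cc3cn(Cc4cccc(Cl)c4)nn3)C/C(=C\c3ccc(C)cc3)C2=O)cc1` gives 33100 nM

Compound 3 lies within the scatter of compound 2, while compound 1 has a lower number than compound 3 by more than the scatter. The change to compound 4 `Cc1ccc(/C=C2\CN(Cc3cn(Cc4ccccc4F)nn3)C/C(=C\c3ccc(C)cc3)C2=O)cc1` reads 2-fluorophenyl in place of 3-chlorophenyl on a saturated chain carbon bound to an aromatic nitrogen and puts 2-fluorophenyl in place of 3-chlorophenyl on a saturated chain carbon bound to an aromatic nitrogen. Going by the values given here, the only measured step at this place is a 1.5-fold lower number from compound 2 to compound 3 (0.18 log units; within the scatter) and it stays within the scatter. Compound 1 shares the 3-chlorophenyl of compound 3, so it does not inform this exchange. Among the compounds with values here, no measured compound carries 2-fluorophenyl at this place, so the expectation rests on a single step. In this assay the expected step is a 1.1-fold higher number from compound 3 to compound 4 (0.06 log units; within the scatter) and so none beyond the scatter, with no firm direction. For compound 4 the estimated value is 38000 nM with an expected range from 18000 nM to 75000 nM on present data.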

Compound 4, half-maximal inhibitory concentration: 9500 nM
For compound 4 the middle estimate is 4.0-fold (0.60 log units) above the measured one, outside the stated range (below it).
By their numbers in this assay, from the lowest: compound 1; then compound 4; then compounds 3 and 2 (each within the scatter of the next).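

In this assay the aryl group on a saturated chain carbon bound to an aromatic nitrogen now shows a change beyond the scatter, with a 3.5-fold lower number from compound 3 to compound 4 (0.54 log units; beyond the scatter) and a 5.2-fold lower number from compound 2 to compound 4 (0.72 log units; beyond the scatter) as the two readings, whereas a 1.5-fold lower number from compound 2 to compound 3 (0.18 log units; within the scatter) gave no such separation. Compound 2 and compound 4 both carry a fluorine on this ring, so its presence alone does not set the number here, and 2-fluorophenyl stands apart from both 4-fluorophenyl and 3-chlorophenyl in this series. No measurement on hand accounts for this difference.

From the compounds shown here alone, whether 2-fluorophenyl in place of 3-chlorophenyl gives a similar step on the core of compound 1 remains open. Also open, going by these compounds, is how a plain phenyl or a 2-chlorophenyl would read at this place.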